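A few compounds are considered here, and "the series" means these few. Any claim that something is new, unique, unknown or untested is made for them only; others in the source may bear on it.

Working notes on the series. Compound 1 `COc1cc(/C=C/C(=O)C2=C(/C=C/c3ccc(O)c(OC)c3)NC(=O)NC2c2ccccc2O)ccc1O` and compound 2 `COc1cc(/C=C/C(=O)C2=C(/C=C/c3ccc(O)c(OC)c3)NC(=O)NC2c2c(Cl)cccc2Cl)ccc1O` share one core and differ only in the aryl group on the saturated ring carbon. In a functional assay, with a stated time of 20 min, tested at 10 uM (a lower number here means a weaker effect, a higher number a stronger effect of the compound at the concentration tested), compound 1 gives 73.6%. In this assay compound 2 gives 19.2%. For the measured compounds named here, the single measured step is a number 54.4 percentage points lower from compound 1 to compound 2 (beyond the scatter), so compound 2 stands lowest of the two numbers known so far, with compound 1 as its only neighbour and well beyond the scatter above it.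

Compound 3 `COc1cc(/C=C/C(=O)C2=C(/C=C/c3ccc(O)c(OC)c3)NC(=O)NC2c2ccccc2Cl)ccc1O` is compound 2 with the change (hydrogen in place of chloro on an aromatic carbon). Going by the values given here, only the step from compound 1 to compound 2 bears on this, and it shows that replacing 2-hydroxyphenyl with 2,6-dichlorophenyl cost a large amount of activity. Compound 3 removes one of the two chloro groups but does not restore the hydroxyl, so a partial recovery in this assay is expected, an upward step estimated at a number 22.8 percentage points higher from compound 2 to compound 3 (beyond the scatter), though the data contain no direct single-chloro comparison. For compound 3 the expected value in this assay is 42%, with a range from 18% to 68%.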

Compound 3, a percentage reported as activity, at one concentration (the size of the read-out at that concentration, not a potency): 40%
The estimate for compound 3 lay 2 percentage points above the measured number; measured number inside the range.
By their numbers in this assay, from the lowest: compound 2; then compound 3; then compound 1.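

In this assay, hydrogen in place of chloro on the aromatic carbon gives a number 20.8 percentage points higher from compound 2 to compound 3 (beyond the scatter), so the second chloro group on this ring carries a cost of its own, separate from the loss of the hydroxy group. Chloro in place of hydroxy on an aromatic carbon, now seen as a single change with no second chloro group involved, gives a number 33.6 percentage points lower from compound 1 to compound 3 (beyond the scatter), a larger step, so the earlier drop with the 2,6-dichlorophenyl group divides into two parts, each beyond the scatter. Nothing measured here gives a reason for either step.

From the compounds shown here alone, whether hydrogen, an amine or a methoxy group on that same aromatic carbon would bring the number closer to that of compound 1 stays open, so it cannot yet be said how much of the gap depends on the hydroxy group itself and how much on the presence of chloro. The three compounds also say nothing about changes elsewhere on the shared core, and a read-out at one concentration leaves their potency unknown.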